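The compounds below may be only part of what the source reports. "The series", "measured", "known", "first", "only" and "open" are said of these compounds alone.

Compound 1 `COc1cc2nc(C3CCC3)nc(N3CCN(c4ccccc4)CC3)c2cc1OC`: in an in vitro assay on U2OS cells for agonist activity at neurotensin receptor type 2 (Homo sapiens), read by reporter gene assay and beta-arrestin recruitment (on this read-out lower numbers stand for an effect already at smaller amounts and higher numbers for an effect only at larger amounts of compound), compound 1 gives > 80000 nM, which is a limit of the assay.
Compound 2 `COc1cc2ncnc(N3CCN(c4ccccc4OC)CC3)c2cc1OC`: in this assay compound 2 gives > 80000 nM, again only a limit.
Compound 3 `COc1cc2nc(C3CCCC3)nc(N3CCN(c4ccccc4OC)CC3)c2cc1OC`: in this assay compound 3 gives > 80000 nM, also a limit.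

Compound 2 therefore stands nowhere on a scale in this assay; all three measured compounds sit at the same limit, so no order among them can be read. The unmeasured compound 4 `COc1cc2nc(CC3CC3)nc(N3CCN(c4ccccc4OC)CC3)c2cc1OC` differs from compound 2 by cyclopropylmethyl in place of hydrogen on an aromatic carbon. Within the data shown here, the only measured step that resembles this change, a step that the two limits leave unreadable from compound 2 to compound 3, has both ends at the limit, and its size stays hidden because of the limit of > 80000 nM in this assay, at which 3 of the 3 values shown sit. The step from compound 2 to compound 4 in this assay is thus expected to be a number no higher from compound 2 to compound 4 (the limit leaves the size open), that is, not readable beyond the limit. Compound 4 is accordingly estimated at 80000 nM, with a range from 20000 nM to 300000 nM.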

Compound 4, half-maximal effective concentration: > 80000 nM
Compound 4 was reported as a limit; the forecaster's own chance of this, stated with the estimate: 85%; the middle value lies on the limit itself.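

No step from compound 2 or compound 3 to compound 4 can be read, because all of these compounds end at the same limit: the limit of > 80000 nM in this assay, at which 4 of the 4 values shown sit.

The compounds shown leave open whether any of them has a measurable effect in this assay, and how the groups compare.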